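The source may hold more compounds than are shown below. What is called first, only, known or untested is meant among the compounds shown, and "the series" means these compounds.

In an assay for inhibition of Nitric oxide synthase, inducible (Homo sapiens), read by scintillation counting, with a stated time of 30 min, tested at 1 mM (on this read-out lower numbers stand for less inhibition and higher numbers for more inhibition at the one concentration tested (going by the name of the read-out)), compound 2 `CCCNC(=O)NCCC(O)c1ccccc1N` gives 19%. For the measured compounds named here, compound 1 `CCNC(=O)NCCC(O)c1ccccc1N` gives 18.3%, so the only step measured so far, a number 0.7 percentage points higher from compound 1 to compound 2 (within the scatter), stays within the scatter, and compound 2 stands level with compound 1 rather than apart from it. Compound 3 `Nc1ccccc1C(O)CCNC(=O)Nc1ccccc1` differs from compound 2 by phenyl in place of propyl on an amide-type nitrogen. Trading propyl for phenyl has no measured counterpart here; the one known step, a small lengthening of the chain, barely moved the number. Compound 3 is therefore expected to show no step beyond the scatter, a number 1 percentage points higher from compound 2 to compound 3 (within the scatter), with an estimate of 20% and a range from 5% to 40%.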

Compound 3, a percentage reported as inhibition, at one concentration (the size of the read-out at that concentration, not a potency): 27.9%
Beside the measured number, compound 3's estimate is 7.9 percentage points below it; the range from low to high includes it.
By their numbers in this assay, from the lowest: compounds 1, 2 and 3 (each within the scatter of the next).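

In this assay the amide-type nitrogen carries an aromatic ring as readily as a saturated chain: phenyl in place of propyl gives a number 8.9 percentage points higher from compound 2 to compound 3 (within the scatter) and phenyl in place of ethyl gives a number 9.6 percentage points higher from compound 1 to compound 3 (within the scatter) and so even this larger swap stays inside the scatter. Compound 3 therefore stands level with both chain compounds, and no clear effect of the change can be claimed. No outside evidence bears on these steps.

On these data alone, whether a benzyl or cyclohexyl group on this nitrogen would move the number beyond the scatter stays open. So does the effect of a chlorine or methoxy group on the phenyl ring.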